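This account rests on a few compounds, and the source may have more. Where it says the series, first, only, none or still open, it means among the compounds named here.

Of the compounds shown here, two that share one core have so far been measured in a functional assay on A498 cells (Homo sapiens) for inhibition, read by sulforhodamine B assay, with a stated time of 48 h, tested at 10 uM; on this read-out lower numbers stand for a stronger effect and higher numbers for a weaker effect at the one concentration tested. Compound 1 `COc1cc(Cl)cc(-c2nn(-c3cccc(NC(=O)Nc4cc(C(F)(F)F)cc(C(F)(F)F)c4)c3)cc2-c2ccncc2)c1` gives -21.6% in this assay. Compound 2 `COc1cc(Cl)cc(-c2nn(-c3cccc(NC(=O)Nc4ccc(Cl)c(Cl)c4)c3)cc2-c2ccncc2)c1` gives -9.54% in this assay, which is the higher of the two numbers, and the gap between the two compounds is beyond the usual scatter. For the measured compounds named here, the two structures differ in more than one place, so no single step joins them. A third compound, compound 3 `COc1cc(Cl)cc(-c2nn(-c3cccc(NC(=O)Nc4cccc(C(F)(F)F)c4)c3)cc2-c2ccncc2)c1`, has not yet been measured. It differs from compound 2 in a single place: 3-(trifluoromethyl)phenyl in place of 3,4-dichlorophenyl on an amide-type nitrogen. Going by the values given here, nothing measured so far isolates that change on its own. The expected step in this assay is a number 5.5 percentage points lower from compound 2 to compound 3 (within the scatter), small, if anything toward a lower number, and not clearly beyond the scatter. Compound 3 is therefore estimated at -15% in this assay, with a range from -35% to 5%.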

Compound 3, a percentage reported as activity, at one concentration (the size of the read-out at that concentration, not a potency): -6.74%
The estimate for compound 3 lay 8.3 percentage points below the measured number, and the stated range covers the measured number.
By their numbers in this assay, from the lowest: compound 1; then compounds 2 and 3 (each within the scatter of the next).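

In this assay, 3-(trifluoromethyl)phenyl in place of 3,4-dichlorophenyl on the amide-type nitrogen gives a number 2.8 percentage points higher from compound 2 to compound 3 (within the scatter), so this exchange does not separate the two compounds on this read-out. Hydrogen in place of trifluoromethyl on an aromatic carbon gives a number 14.9 percentage points higher from compound 1 to compound 3 (beyond the scatter), the first single-place step here that goes beyond the scatter, which shows that among these compounds the aryl group on this nitrogen does matter, with the second trifluoromethyl of compound 1 going with the stronger effect. Nothing at hand accounts for either step. From the compounds shown here alone, how a nitrile, a methoxy or an amine on this aryl ring would read remains open. So does whether the step from the second trifluoromethyl would recur with a chlorine in its place.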